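Oxime to acetyl on the anilide of compound 1

The source may hold more compounds than are shown below. What is called first, only, known or untested is meant among the compounds shown, and "the series" means these compounds.

Measured so far:
In a functional assay on UACC-62 cells (Homo sapiens) for inhibition, read by sulforhodamine B assay, with a stated time of 48 h, tested at 10 uM (on this read-out lower numbers stand for less inhibition of growth and higher numbers for more inhibition of growth at the one concentration tested), compound 1 `C/C(=N\O)c1ccc(NC(=O)Cn2nc(-c3ccc(Cl)cc3)nc2N)cc1` gives 8.96%.
In this assay compound 2 `COc1cc(-c2nc(N)n(CC(=O)Nc3ccc(/C(C)=N\O)cc3)n2)cc(OC)c1OC` gives 16.4%.
In this assay compound 3 `c1ccc(-c2nc3sc(-c4ccccc4)cn3n2)cc1` gives 33%.

Compound 1 holds the lowest of the three numbers. Compound 2 lies within the scatter of compound 1, so the two cannot be placed in order. Going by the values given here, compound 3 sits beyond the scatter above compound 1; it shares no core with compound 1, and no two of the measured compounds differ in one place, so no single-site step is at hand.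

Compound 4 `CC(=O)c1ccc(NC(=O)Cn2nc(-c3ccc(Cl)cc3)nc2N)cc1` is the next compound in the series. Compared with compound 1 the change is a group of 3 heavy atoms (2 carbon, 1 oxygen; no ring) in place of a group of 4 heavy atoms (2 carbon, 1 nitrogen, 1 oxygen; no ring), on an aromatic carbon. Among the compounds with values here, with no single-site step among the measured compounds, nothing shows how a change of this kind moves the read-out, and compound 1 already stands near the bottom of the range. The step from compound 1 to compound 4 in this assay is therefore expected to be a number 3 percentage points higher from compound 1 to compound 4 (within the scatter), that is, none beyond the scatter. Compound 4 is estimated at 12%, with a range from 0% to 26%.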

Compound 4, percent growth inhibition at one concentration: 6.29%
Beside the measured number, compound 4's estimate is 5.7 percentage points above it; low and high end bracket the measured number.
By their numbers in this assay, from the lowest: compounds 4, 1 and 2 (each within the scatter of the next, the first and the last beyond it); then compound 3.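

In this assay the series now has its first single-site step: acetyl in place of the group of 4 heavy atoms, on an aromatic carbon para to a large group, gives a number 2.7 percentage points lower from compound 1 to compound 4 (within the scatter) and so leaves the two compounds unordered. The read-out at this position therefore does not separate the group with 1 hydrogen-bond donor and 2 hydrogen-bond acceptors from acetyl with 0 hydrogen-bond donors and 1 hydrogen-bond acceptor, though this holds only for this one pair, on the core of compound 1, at the one concentration tested. No measurement shown here offers an explanation for this outcome.

As far as these compounds go, whether an amine, a carboxylic acid or a longer chain on this aromatic carbon would move the read-out beyond the scatter from compound 1 remains open. Also open, from the compounds shown here alone, is whether acetyl in the same place on the core of compound 2 would give a step of similar size, since a single pair cannot show whether this result carries over to a different substitution elsewhere on the core.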